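Chloro for methoxy with only assay limits to go on

A few compounds are considered here, and "the series" means these few. Any claim that something is new, unique, unknown or untested is made for them only; others in the source may bear on it.

Compound 1, `COc1ccc(-c2nnc(N3CCN(C(=O)CN4CCN(c5ccccc5)CC4)CC3)nc2-c2ccc(OC)cc2)cc1`, in an ADME assay on NIH3T3 cells (Mus musculus) for cytotoxicity, read by MTT assay, with a stated time of 24 h (a lower number here means a stronger inhibitor, a higher number a weaker inhibitor), gives > 863000 nM, a limit of the assay and not a number.
Compound 2, `COc1ccc(-c2nnc(N3CCN(C(=O)CN4CCN(c5cccc(OC)c5)CC4)CC3)nc2-c2ccc(OC)cc2)cc1`, in this assay gives > 821000 nM, again a limit of the assay.

For the measured compounds named here, compound 2 therefore stands at a limit, and the one further value shown is a limit as well. Going by the values given here, the step that the two limits leave unreadable from compound 1 to compound 2 is the only measured comparison, and because both of its ends sit at limits the limit of > 821000 nM in this assay, at which 1 of the 2 values shown sits, the limit of > 863000 nM in this assay, at which 1 of the 2 values shown sits, its size cannot be read. Compound 3, `COc1ccc(-c2nnc(N3CCN(C(=O)CN4CCN(c5cccc(Cl)c5)CC4)CC3)nc2-c2ccc(OC)cc2)cc1`, differs from compound 2 by chloro in place of methoxy on an aromatic carbon. No measured step with a readable size bears on this exchange, as the single step shown, methoxy in place of hydrogen, stays unreadable. The expectation for compound 3 rests only on compound 2 reaching no number in this assay. The expected value for compound 3 is 900000 nM, with a range from 300000 nM to 3000000 nM, and most likely again only a limit. The step that the limit leaves unreadable from compound 2 to compound 3 is thus expected to be none beyond the scatter.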

Compound 3, half-maximal inhibitory concentration: > 814000 nM
Compound 3 gave a limit, no number; the forecaster's own chance of this, stated with the estimate: 80%; the middle value lies beyond the limit too.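

In this assay, compound 1, compound 2 and compound 3 all sit at limits of the assay and not at numbers; the steps from compound 2 to compound 3 and from compound 1 to compound 3 cannot be read. The compounds shown leave open what concentration of any of the three would reach the half-maximal effect, and whether hydrogen, methoxy or chloro on that aromatic carbon makes any difference.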